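The source may hold more compounds than are shown below. What is called first, only, known or untested is meant among the compounds shown, and "the series" means these compounds.

In a functional assay on CCRF-CEM cells (Homo sapiens), read by MTT assay, with a stated time of 72 h (a lower number here means a stronger inhibitor, a higher number a weaker inhibitor), compound 1 `O=c1[nH]cnc2c1c(-c1ccsc1)cn2[C@@H]1O[C@H](CO)[C@@H](O)[C@H]1O` gives 14500 nM. Compound 2 `O=c1[nH]cnc2c1c(-c1cccs1)cn2[C@@H]1O[C@H](CO)[C@@H](O)[C@H]1O` reaches only the limit of the measurement, > 20000 nM. Compound 3 `Nc1nc2c(c(-c3ccsc3)cn2[C@@H]2O[C@H](CO)[C@@H](O)[C@H]2O)c(=O)[nH]1` likewise reaches only a limit, > 20000 nM, so for compound 3 there is a bound rather than a number. Of the three results shown, the limit of > 20000 nM in this assay, at which 2 of the 3 values shown sit, describes where two of them sit. The step from compound 1 to compound 2 was an at least 1.3-fold higher number from compound 1 to compound 2 (0.13 log units; that floor lies within the scatter), and the step from compound 1 to compound 3 was an at least 1.3-fold higher number from compound 1 to compound 3 (0.13 log units; that floor lies within the scatter). Compound 4 `Nc1nc2c(c(-c3cccs3)cn2[C@@H]2O[C@H](CO)[C@@H](O)[C@H]2O)c(=O)[nH]1` has not been measured; it differs from compound 3 by thiophen-2-yl in place of thiophen-3-yl on an aromatic carbon. The same exchange was already made between compound 1 and compound 2, where it carried the result to the limit. Starting from a compound that is itself already at the limit, a further weakening is expected, a step that the limit leaves unreadable from compound 3 to compound 4, though it could not be resolved by this assay. Compound 4 is therefore expected to give 40000 nM, somewhere between 20000 nM and 100000 nM, most probably reported again only as a limit.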

Compound 4, half-maximal inhibitory concentration: > 20000 nM
Compound 4: no number, only a limit (the forecaster's own chance of this, stated with the estimate: 90%); the middle value lies beyond the limit too.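

Compound 4 ends at a limit rather than a number, as do compound 2 and compound 3, so its steps from those two compounds cannot be read: the limit of > 20000 nM in this assay, at which 3 of the 4 values shown sit. As far as these compounds go, how far compound 2, compound 3 and compound 4 lie past that limit, and whether thiophen-2-yl and thiophen-3-yl differ in the amino compounds, stays open.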